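This account rests on a few compounds, and the source may have more. Where it says the series, first, only, none or still open, it means among the compounds named here.

Measured so far in a functional assay on CWR22R cells (Homo sapiens) for antiproliferative activity, read by propidium iodide staining, with a stated time of 96 h; on this read-out lower numbers stand for stronger inhibition and higher numbers for weaker inhibition:

compound 1, `CC1(C)C(=O)N(c2ccc(S(F)(F)(F)(F)F)cc2)C(=S)N1c1ccc(C(F)(F)F)cc1`, gives 100000 nM
compound 2, `CC1(C)C(=O)N(c2ccc(S(F)(F)(F)(F)F)cc2)C(=S)N1c1cccc(C(F)(F)F)c1`, gives 59600 nM
compound 3, `CC1(C)C(=O)N(c2cccc(S(F)(F)(F)(F)F)c2)C(=S)N1c1ccc(C(F)(F)F)cc1`, gives 22400 nM

Compound 4, `CC1(C)C(=O)N(c2cccc(S(F)(F)(F)(F)F)c2)C(=S)N1c1cccc(C(F)(F)F)c1`, is not yet measured. The change from compound 1 to compound 2 is 3-(trifluoromethyl)phenyl in place of 4-(trifluoromethyl)phenyl on an amide-type nitrogen in a ring, and it made a 1.7-fold lower number from compound 1 to compound 2 (0.22 log units; within the scatter). Compound 3 stands apart from both: the difference between its core and that of compound 1 is not broken down here, and compound 3 carries the lowest of the three numbers, with both other steps to it beyond the scatter. The change from compound 3 to compound 4 is 3-(trifluoromethyl)phenyl in place of 4-(trifluoromethyl)phenyl on an amide-type nitrogen in a ring, the same change as before. Among the compounds with values here, the step from compound 3 to compound 4 is expected to be about a 1.5-fold lower number from compound 3 to compound 4 (0.17 log units; within the scatter), because the single earlier instance gave a 1.7-fold lower number from compound 1 to compound 2 (0.22 log units; within the scatter). Compound 4 is estimated at 15000 nM, between 6000 nM and 40000 nM.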

Compound 4, half-maximal inhibitory concentration: 100000 nM
Beside the measured number, compound 4's estimate is 6.7-fold (0.82 log units) below it, outside the stated range (above it).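

In this assay, 3-(trifluoromethyl)phenyl in place of 4-(trifluoromethyl)phenyl gives a 4.5-fold higher number from compound 3 to compound 4 (0.65 log units; beyond the scatter), so the change does not carry over between the two cores in size or direction: the same change on two cores in this assay, a 1.7-fold lower number (0.22 log units; within the scatter) from compound 1 to compound 2 and a 4.5-fold higher number (0.65 log units; beyond the scatter) from compound 3 to compound 4, 7.5-fold (0.87 log units) apart, beyond the scatter of two such steps. Within the data shown here, for these two pairs, then, the step read on one core is no guide to the step on the other. With one pair per core, this does not show why the cores differ or how the change behaves on any further core.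

The compounds shown leave open whether the same dependence on the core appears when a nitrile or a chlorine takes the place of trifluoromethyl. They also leave open how the series responds when a longer chain replaces the two methyl groups.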